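The source may report more compounds than this note shows. Statements on the series, on what has been measured and on what is new or still open speak of the compounds shown alone.

Measured compounds in a functional assay on Ehrlich cells (Mus musculus) for antiproliferative activity, read by trypan blue exclusion, with a stated time of 2 h, tested at 25 ug/mL; on this read-out lower numbers stand for a weaker effect and higher numbers for a stronger effect at the one concentration tested:
Compound 1 `N#CC1=C(N)N(c2ccc(S(N)(=O)=O)cc2)C2=C(C(=O)CCC2)C1c1ccc(O)cc1` gives 95% in this assay.
Compound 2 `N#CC1=C(N)N(c2ccc(S(N)(=O)=O)cc2)C2=C(C(=O)CCC2)C1/C=C/c1ccccc1` gives 10% in this assay.

For the measured compounds named here, compound 2 stands at the lowest of the two numbers; its only neighbour is compound 1, which lies far higher. Going by the values given here, the single measured step is a number 85 percentage points lower from compound 1 to compound 2 (beyond the scatter), brought about by putting 2-phenylethenyl in place of 4-hydroxyphenyl on a saturated ring carbon. Among the compounds with values here, that is the only guide available for the next change.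

Compound 3 `COc1ccccc1C1C(C#N)=C(N)N(c2ccc(S(N)(=O)=O)cc2)C2=C1C(=O)CCC2` differs from compound 2 in one place: 2-methoxyphenyl in place of 2-phenylethenyl on a saturated ring carbon. The 2-phenylethenyl group, whose arrival coincided with the large fall, leaves again, and an aromatic ring returns to the saturated ring carbon, though as 2-methoxyphenyl rather than the 4-hydroxyphenyl of compound 1. Within the data shown here, a rise in this assay is therefore expected, since the one measured step ran the other way because a number 85 percentage points lower from compound 1 to compound 2 (beyond the scatter) accompanied the opposite exchange; how much of that rise a 2-methoxyphenyl group recovers is uncertain, as no measured compound carries it. Compound 3 is estimated at 60%, with a range from 20% to 95%. The expected step is a number 50 percentage points higher from compound 2 to compound 3 (beyond the scatter).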

Compound 3, a percentage reported as activity, at one concentration (the size of the read-out at that concentration, not a potency): 0%
Beside the measured number, compound 3's estimate is 60 percentage points above it; measured number outside the range, below it.
By their numbers in this assay, from the lowest: compounds 3 and 2 (each within the scatter of the next); then compound 1.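

In this assay, replacing 2-phenylethenyl with 2-methoxyphenyl gives a number 10 percentage points lower from compound 2 to compound 3 (within the scatter), so compound 2 and compound 3 cannot be told apart, and an aromatic ring on this saturated ring carbon is clearly not enough by itself for a strong effect. For the compounds shown here, the comparison with the only strongly active compound gives a number 95 percentage points lower from compound 1 to compound 3 (beyond the scatter), which shows that this position is sensitive not only to whether an aromatic ring is present but also to which substituted ring it is: 4-hydroxyphenyl goes with a strong effect here, 2-methoxyphenyl does not. No measurement at hand explains this difference.

The exchange from 4-hydroxyphenyl to 2-methoxyphenyl alters both the oxygen-bearing group and its place on the ring, so the compounds shown leave open which of the two alterations matters. A 4-methoxyphenyl or a 2-hydroxyphenyl group on the same carbon would separate them, and an unsubstituted phenyl group there would show whether the ring needs any such substituent at all.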